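Acyl chain length and cytotoxicity in the series

This account rests on a few compounds, and the source may have more. Where it says the series, first, only, none or still open, it means among the compounds named here.

Compound 1 `CCCCCCCCCCCC(=O)Nc1nnc(S[C@@H]2O[C@H](COC(C)=O)[C@H](OC(C)=O)[C@H](OC(C)=O)[C@H]2OC(C)=O)s1` and compound 2 `CCCCCCCCCCCCCC(=O)Nc1nnc(S[C@@H]2O[C@H](COC(C)=O)[C@H](OC(C)=O)[C@H](OC(C)=O)[C@H]2OC(C)=O)s1` share an acetylated core. In an ADME assay on CHO-K1 cells (Cricetulus griseus) for cytotoxicity, read by MTT assay, with a stated time of 24 h (on this read-out lower numbers stand for stronger inhibition and higher numbers for weaker inhibition), compound 1 gives 27700 nM, and in this assay compound 2 gives 16300 nM. The change hydrogen in place of ethyl on a saturated chain carbon, ten or more bonds along the chain from a carbonyl carbon yields a 1.7-fold higher number from compound 2 to compound 1 (0.23 log units; within the scatter). Compound 3 `CCCCCCCCCCCCCCCC(=O)Nc1nnc(S[C@@H]2O[C@H](CO)[C@H](O)[C@H](O)[C@H]2O)s1` carries a deacetylated core; how that core differs from the core of compound 2 is not broken down here. In this assay compound 3 is reported as not active, with "not active" (no number reported) and no number given. Compound 4 `CCCCCCCCCCCCCC(=O)Nc1nnc(S[C@@H]2O[C@H](CO)[C@H](O)[C@H](O)[C@H]2O)s1` has not been measured; it differs from compound 3 by hydrogen in place of ethyl on a saturated chain carbon, ten or more bonds along the chain from a carbonyl carbon, the same change as from compound 2 to compound 1. Because that earlier step was a 1.7-fold higher number from compound 2 to compound 1 (0.23 log units; within the scatter), compound 4 is expected to stay close to compound 3 and may again return no number; the estimate for compound 4 in this assay is 40000 nM.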

Compound 4, half-maximal inhibitory concentration: "not active" (no number reported)
No number was reported for compound 4; no gap can be computed for the estimate.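

Compound 3 and compound 4 both stand without a number in this assay and no step can be read between them. No evidence on file bears on this result.

The compounds shown leave open whether chain length matters at all on the deacetylated core.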